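Nitro for Chloro on the Pendant Ring of Compound 2

The source may hold more compounds than are shown below. What is called first, only, known or untested is meant among the compounds shown, and "the series" means these compounds.

Measured compounds:
Compound 1 `O=[N+]([O-])c1ccccc1-c1nc2ccccc2[nH]1` — 3.07
Compound 2 `O=C(c1cccnc1)n1c(-c2ccccc2Cl)nc2ccccc21` — 4.7
Compound 3 `O=C(c1cccnc1)n1c(-c2ccc(O)cc2)nc2ccccc21` — 3.89

In a physicochemical assay for lipophilicity, measured as octanol-water partition (a lower number here means a more polar compound, a higher number a more lipophilic compound), compound 2 gives 4.7, the highest of the three numbers; compound 3 lies nearest with 3.89, and furthest, differing from compound 2 in more than one place, stands compound 1 with 3.07. Compound 4 `O=C(c1cccnc1)n1c(-c2ccccc2[N+](=O)[O-])nc2ccccc21` has not yet been measured in this assay. Among the compounds with values here, its single change from compound 2 is nitro in place of chloro on an aromatic carbon. Within the data shown here, the one measured step of the set, a number 0.81 log units lower from compound 2 to compound 3 (beyond the scatter), bears on it only loosely, since there a hydroxyl entered as well as chloro leaving. Moving from chloro to nitro is expected to pull the partition coefficient down by a modest amount, beyond the scatter but smaller than the step to compound 3, so that a number 0.85 log units lower from compound 2 to compound 4 (beyond the scatter) is the estimated step. Compound 4 is therefore expected to give 3.85 in this assay, with a likely range from 3.35 to 4.35.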

Compound 4, partition coefficient: 4.13
The estimate for compound 4 lay 0.28 log units below the measured number; the range from low to high includes it.
By their numbers in this assay, from the lowest: compound 1; then compounds 3 and 4 (each within the scatter of the next); then compound 2.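

With the change confined to one place, on an aromatic carbon ortho to a large group, nitro in place of chloro gives a number 0.57 log units lower from compound 2 to compound 4 (beyond the scatter) in this assay, so this position responds to a swap that involves no hydroxyl. Within the data shown here, compound 4 also links the pendant-ring series to compound 1: with nitro held fixed, (pyridin-3-yl)carbonyl in place of hydrogen on the aromatic nitrogen gives a number 1.06 log units higher from compound 1 to compound 4 (beyond the scatter), the first reading of that change alone. Nothing available here accounts for either step.

From the compounds shown here alone, whether an amine, a methoxy group or a nitrile at this same place would follow nitro or chloro remains open. So does whether the step at the aromatic nitrogen would keep its size with chloro on the pendant ring instead of nitro.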